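A few compounds are considered here, and "the series" means these few. Any claim that something is new, unique, unknown or untested is made for them only; others in the source may bear on it.

Measured compounds:
- compound 1, `CN(C)c1c(C#N)c2c(N)ncnc2n1C`, 111 nM in an assay on isolated protein for binding affinity to Leucine-rich repeat serine/threonine-protein kinase 2 (Homo sapiens), read by TR-FRET and LanthaScreen, with a stated time of 2 h; a higher number here means a weaker inhibitor, a lower number a stronger inhibitor
- compound 2, `C[C@@H]1CCCN1c1c(C#N)c2c(N)ncnc2n1C`, 0.4 nM in this assay
- compound 3, `Cn1c(N)c(C#N)c2c(N)ncnc21`, 346 nM in this assay

Compound 3 gives the highest number of the three, so it is the weakest binder here. Its nearest neighbour is compound 1, with a 3.1-fold higher number from compound 1 to compound 3 (0.49 log units; beyond the scatter); its furthest is compound 2, with an 870-fold higher number from compound 2 to compound 3 (2.94 log units; beyond the scatter). The step to compound 4, `Cn1c(-n2cccc2)c(C#N)c2c(N)ncnc21`, is this: 1H-pyrrol-1-yl in place of amino on an aromatic carbon.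

For the measured compounds named here, two measured steps bear on it, both ending at compound 3 and both swapping the group on the same carbon. The change from dimethylamino to amino, a 3.1-fold higher number from compound 1 to compound 3 (0.49 log units; beyond the scatter), was modest. The change from 2-methylpyrrolidin-1-yl to amino, an 870-fold higher number from compound 2 to compound 3 (2.94 log units; beyond the scatter), was large. Compound 4 moves in the opposite direction, replacing amino with a five-membered nitrogen ring attached through its nitrogen, which is closest in kind to the reversal of the step from compound 2 to compound 3. That ring is aromatic and planar, unlike 2-methylpyrrolidin-1-yl, so the full reversal is not assumed.

Compound 4 is therefore expected to give a clearly lower number in this assay than compound 3, a step estimated as a 23-fold lower number from compound 3 to compound 4 (1.36 log units; beyond the scatter). The estimated value for compound 4 is 15 nM, with a range from 3 nM to 80 nM.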

Compound 4, inhibition constant: 239 nM
Beside the measured number, compound 4's estimate is 16-fold (1.20 log units) below it, and the stated range ends below it.
By their numbers in this assay, from the lowest: compound 2; then compound 1; then compounds 4 and 3 (each within the scatter of the next).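

In this assay, 1H-pyrrol-1-yl in place of amino on this aromatic carbon gives a 1.4-fold lower number from compound 3 to compound 4 (0.16 log units; within the scatter) and so does not separate the two compounds, which shows that a five-membered nitrogen ring attached through its nitrogen is not enough on its own to reproduce what 2-methylpyrrolidin-1-yl gives here. The two rings lie far apart at this position (a 600-fold higher number from compound 2 to compound 4 (2.78 log units; beyond the scatter)), while 1H-pyrrol-1-yl also falls modestly short of the small dimethylamino group (a 2.2-fold higher number from compound 1 to compound 4 (0.33 log units; beyond the scatter)), so among the four compounds only 2-methylpyrrolidin-1-yl stands well apart, and size alone, counted in heavy atoms, does not order them. Nothing available explains why the two rings differ so much.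

The compounds shown leave open whether the ring or its methyl group carries the effect of 2-methylpyrrolidin-1-yl, a question that plain pyrrolidin-1-yl would address, along with the mirror-image form of 2-methylpyrrolidin-1-yl. They also leave open how an open-chain amine such as diethylamino, or a larger ring such as piperidin-1-yl, would compare on this same carbon.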